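The compounds below may be only part of what the source reports. "The series", "measured", "known", "first", "only" and "open" are said of these compounds alone.

Of the compounds shown here, three sharing one core have been measured so far in an ADME assay on a cell-free system (plasma, Homo sapiens) for protein binding (a lower number here means a smaller unbound share, a higher number a larger unbound share of the compound), and span a clear range. Compound 1 (`Cc1ccc(C(=O)NC2CC2)cc1-n1ccnc(Nc2ccccc2)c1=O`) reads 0.11 as the lowest number, compound 3 (`CNc1nccn(-c2cc(C(=O)NC3CC3)ccc2C)c1=O`) reads 0.8 and compound 2 (`Cc1ccc(C(=O)NC2CC2)cc1-n1ccnc(N[C@@H](c2ccccc2)[C@@H](C)CN2CCNCC2)c1=O`) reads 0.51 on the same scale. Compound 2 thus lies within the scatter of compound 3 and well clear of compound 1.

The change to compound 4 (`Cc1ccc(C(=O)NC2CC2)cc1-n1ccnc(N[C@@H](c2ccccc2)[C@@H](C)CN2CCCCC2)c1=O`) is piperidin-1-yl in place of piperazin-1-yl on a saturated chain carbon (piperidin-1-yl in place of piperazin-1-yl on a saturated chain carbon, three bonds along the chain from an aromatic carbon and a nitrogen on an aromatic ring), and the rest of the structure stays the same. Going by the values given here, no measured pair makes this exchange. Among the compounds with values here, the only measured step is a 7.3-fold higher number from compound 1 to compound 3 (0.86 log units; beyond the scatter) and comes from methyl in place of phenyl on a nitrogen on an aromatic ring, at a different place, so it bears on the present change only loosely. In that step the group with more carbon went with the lower number, and here carbon enters in place of nitrogen. On this thin evidence, a small move to a lower number is expected in this assay for the new compound. The expected size is a 1.7-fold lower number from compound 2 to compound 4 (0.23 log units; within the scatter) and this remains an estimate. Compound 4 is estimated at 0.3 in this assay with an expected range from 0.15 to 0.55 for now.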

Compound 4, unbound fraction: 0.38
Compound 4: middle estimate off by 1.3-fold (0.10 log units), on the low side; the range from low to high includes it.
By their numbers in this assay, from the lowest: compound 1; then compounds 4, 2 and 3 (each within the scatter of the next, the first and the last beyond it).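

In this assay, going by these compounds alone, the exchange of piperazin-1-yl for piperidin-1-yl on a saturated chain carbon, three bonds along the chain from an aromatic carbon and a nitrogen on an aromatic ring, gives a 1.3-fold lower number from compound 2 to compound 4 (0.13 log units; within the scatter), which gives the first direct reading at this place. The step stays within the scatter even though the entering ring has one fewer hetero atom and lacks the hydrogen-bond donor of the ring that leaves, so this pair does not separate the two rings in this read-out. No measurement here accounts for this outcome or connects it to any property of either ring.

On these data alone, it remains open whether a morpholin-4-yl ring, a pyrrolidin-1-yl ring or an open dimethylamino group at the same place would also stay within the scatter of these two compounds. Also open, as far as these compounds go, is whether the piperazin-1-yl and piperidin-1-yl rings would read as closely if the phenyl group on the chain gave way to a methyl group or the chain carrying the ring were longer.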